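Chloro in Place of Hydrogen on the Pyridin-2-yl Ring

The source may hold more compounds than are shown below. What is called first, only, known or untested is meant among the compounds shown, and "the series" means these compounds.

Compound 1 `Cc1ccc(Oc2ccc3nc(COc4cccc(C(=O)O)c4)n(C)c3n2)c(C)c1` gives 0.9 ug/mL in a physicochemical assay for solubility, read by HPLC, measured as thermodynamic solubility, with a stated time of 4 h, at pH 6.8; on this read-out higher numbers stand for higher solubility and lower numbers for lower solubility.
Compound 2 `Cn1c(COc2cccc(C(=O)O)c2)nc2ccc(Oc3ccccn3)cc21` gives 62 ug/mL in this assay.

Of the two numbers in hand, compound 2 stands highest; compound 1 sits far below it, and the gap between the two values lies well beyond the scatter of the method. Among the compounds with values here, the two compounds differ in more than one place, so no single step connects them and their values can only be set side by side.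

Compound 3 `Cn1c(COc2cccc(C(=O)O)c2)nc2ccc(Oc3cccc(Cl)n3)cc21` differs from compound 2 in one place: chloro in place of hydrogen on an aromatic carbon. No measured pair among these compounds shows this change, so its size in this assay cannot be read from data here. On the numbers available, a downward step of modest size is expected, not certainly beyond the scatter. The step is estimated as a 3.1-fold lower number from compound 2 to compound 3 (0.49 log units; beyond the scatter). Compound 3 is therefore expected to give 20 ug/mL in this assay, with a range from 5 ug/mL to 60 ug/mL.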

Compound 3, solubility: 7.7 ug/mL
Compound 3: the middle estimate sits 2.6-fold (0.41 log units) above what was measured, and the stated range covers the measured number.
By their numbers in this assay, from the lowest: compound 1; then compound 3; then compound 2.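

Within the data shown here, the replacement of hydrogen by chloro, turning pyridin-2-yl into 6-chloropyridin-2-yl, gives the first step that can be read at a single place, and in this assay it comes to an 8.1-fold lower number from compound 2 to compound 3 (0.91 log units; beyond the scatter). It shows that this position, on an aromatic carbon next to the ring nitrogen, is not silent on this read-out: one chlorine, a single heavy atom, is enough to carry the number beyond the scatter, although the step is modest. Nothing available here bears on why the number moves as it does.

Among these compounds, the single pair cannot separate what belongs to chloro from what belongs to this carbon, so the reading of this position would change with a methyl, a fluoro or an amine on the same carbon, or with chloro on another carbon of the pyridin-2-yl ring. Also open, from the compounds shown here alone, is whether the same change carries over to other compounds, since it is seen here only on the aryl ether of compound 2 and a second pair of this kind would be needed to show that the step repeats.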